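Adding One Chloro to a Weak Growth Inhibitor

The source may report more compounds than this note shows. Statements on the series, on what has been measured and on what is new or still open speak of the compounds shown alone.

In a functional assay on Hs-578T cells (Homo sapiens) for inhibition, read by sulforhodamine B assay, with a stated time of 48 h (a lower number here means a stronger inhibitor of growth, a higher number a weaker inhibitor of growth), compound 1 (`N#Cc1c(-c2nnc(O)c3nn(-c4ccc(Cl)cc4)cc23)nn(-c2ccccc2)c1-c1ccccc1`) gives > 100000 nM as its reading, which is a limit of the assay and not a number. Going by the values given here, compound 2 (`N#Cc1c(-c2nnc(-c3ccccc3)c3nn(-c4ccccc4)cc23)nn(-c2ccccc2)c1-c1ccccc1`) gives 31800 nM as the only true number so far, so it is the sole firm reference point. Compound 3 (`N#Cc1c(-c2nnc(-c3ccccc3)c3nn(-c4ccc(Cl)cc4)cc23)nn(-c2ccccc2)c1-c1ccccc1`) differs from compound 2 in one place: phenyl becomes 4-chlorophenyl, with chloro in place of hydrogen on an aromatic carbon. Among the compounds with values here, no measured pair of compounds shows what this change does. In this assay, therefore, no shift beyond the usual scatter is expected, and either direction remains possible. The estimated step of a 1.1-fold lower number from compound 2 to compound 3 (0.03 log units; within the scatter) is accordingly expected to be small. This expectation rests on compound 2 (31800 nM) as the starting point. For compound 3, the expected value is 30000 nM (10000 nM to 90000 nM).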

Compound 3, concentration for 50% growth inhibition: 16800 nM
Estimate against measurement, compound 3: 1.8-fold (0.25 log units) above; measured number inside the range.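

In this assay, chloro in place of hydrogen on an aromatic carbon, para to a large group, now has a measured effect: a 1.9-fold lower number from compound 2 to compound 3 (0.28 log units; within the scatter), so at this place the change is no larger than repeat measurements could produce. With 4-chlorophenyl kept the same, the other place in the core proves the more telling one, since phenyl in place of hydroxy on an aromatic carbon gives an at least 5.9-fold lower number from compound 1 to compound 3 (0.77 log units; beyond the scatter). The true size of that step stays unknown because compound 1 stands at a limit and not at a number: the limit of > 100000 nM in this assay, at which 1 of the 3 values shown sits.

As far as these compounds go, it remains open whether another group in the place of the chloro, such as methoxy, an amine or a carboxylic acid, would move the reading beyond the scatter. From the compounds shown here alone, it is equally open how a methyl or a longer chain would read where compound 1 carries hydroxy.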